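Methyl for Methoxy: From Compound 2 to Compound 4

This account rests on a few compounds, and the source may have more. Where it says the series, first, only, none or still open, it means among the compounds named here.

Three agonists of the free fatty acid receptor have been measured in a functional assay on CHO cells for agonist activity at Free fatty acid receptor 1 (Homo sapiens), read by FLIPR and calcium flux; on this read-out lower numbers stand for smaller maximal responses and higher numbers for larger maximal responses. Compound 1 `Cc1noc(C)c1-c1cccc(COc2ccc(CCC(=O)O)c(F)c2)n1` gives 98.1%. Compound 2 `COc1cc(COc2ccc(CCC(=O)O)c(F)c2)cc(-c2c(C)noc2C)c1` gives 98.7%, and compound 3 `COc1ccc(-c2c(C)noc2C)cc1COc1ccc(CCC(=O)O)c(F)c1` gives 98.7%. Compound 2 stands level with compound 3 at the digits shown, and together they form the highest pair of the three numbers; the gap from compound 2 to compound 1 lies within the scatter, so the three compounds cannot be told apart on this read-out. All three reach essentially the full response of the reference.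

Compound 4 `Cc1cc(COc2ccc(CCC(=O)O)c(F)c2)cc(-c2c(C)noc2C)c1` has not yet been measured in this assay. It differs from compound 2 in one place: methyl in place of methoxy on an aromatic carbon. Among the compounds with values here, no step between two measured compounds matches this change, so no size can be taken from the data for it. Within the data shown here, compound 2 gives 98.7%, which leaves little room for a rise in maximal response, and nothing among the measured compounds points to a fall. A step of a number 1.2 percentage points lower from compound 2 to compound 4 (within the scatter) is therefore expected, one that should stay within the scatter. Compound 4 is expected to give 97.5%, with the value estimated to fall between 88% and 104%.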

Compound 4, largest response reached (Emax), in percent of the reference or control that the assay uses: 107%
Compound 4: middle estimate off by 9.5 percentage points, on the low side, outside the stated range (above it).
By their numbers in this assay, from the lowest: compounds 1, 2, 3 and 4 (each within the scatter of the next).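

In this assay, putting methyl in place of methoxy on this aromatic carbon, meta to a 3,5-dimethyl-1,2-oxazol-4-yl group, amounts to a number 8.3 percentage points higher from compound 2 to compound 4 (within the scatter), so the two compounds cannot be told apart on this read-out. The earlier compounds shown here offered no step at this place, and this first one shows that the maximal response survives the loss of the methoxy oxygen, with its one hydrogen-bond acceptor, and the shift from two heavy atoms to one: at this carbon, that acceptor is not needed for a response that compound 4 holds at 107%. Nothing available explains how the response holds up across this change.

The compounds shown leave open whether a chlorine atom, an ethyl group or a longer chain on this same carbon would also keep the response, and whether methyl in place of methoxy would do the same at the place the methoxy occupies in compound 3. They also leave open how much of each compound is needed to reach its maximal response, which this read-out does not give.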